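This account rests on a few compounds, and the source may have more. Where it says the series, first, only, none or still open, it means among the compounds named here.

Measured so far in an ADME assay on HepG2 2.2.15 cells (Homo sapiens) for cytotoxicity, read by MTT assay; on this read-out higher numbers stand for lower toxicity in this test and lower numbers for higher toxicity in this test:
- compound 1, `C=C1CC[C@@H]2[C@](C)(COC(=O)c3ccco3)[C@H](O)CC[C@@]2(C)[C@@H]1C/C=C1\C=COC1=O`: > 2150000 nM
- compound 2, `C=C1CC[C@@H]2[C@](C)(COC(=O)c3cccs3)[C@H](O)CC[C@@]2(C)[C@@H]1C/C=C1\C=COC1=O`: 2470000 nM
- compound 3, `C=C1CC[C@@H]2[C@](C)(CO)[C@H](OC(=O)c3ccco3)CC[C@@]2(C)[C@@H]1C/C=C1\C=COC1=O`: 42000 nM.

For compound 1 the figure is a limit of this assay, not a number. Compound 2 differs from compound 1 by thiophen-2-yl in place of furan-2-yl on a carbonyl carbon, and the step between them, a step that the limit leaves unreadable from compound 1 to compound 2, cannot be sized because of the limit of > 2150000 nM in this assay, at which 1 of the 3 values shown sits. Compound 3 shares its atoms with compound 1 but joined differently; the difference between the two cores is not broken down here. Compound 3 gives the lowest of the two readable numbers, and stands well apart from compound 2.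

Compound 4, `C=C1CC[C@@H]2[C@](C)(CO)[C@H](OC(=O)c3cccs3)CC[C@@]2(C)[C@@H]1C/C=C1\C=COC1=O`, differs from compound 3 by thiophen-2-yl in place of furan-2-yl on a carbonyl carbon, the same change at the same place as from compound 1 to compound 2. Since that earlier step left compound 2 close to the limit that compound 1 sits at, the step of a 1.2-fold higher number from compound 3 to compound 4 (0.08 log units; within the scatter) is expected to be small. Compound 4 is therefore estimated to give about 50000 nM, between 15000 nM and 160000 nM.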

Compound 4, half-maximal cytotoxic concentration: 257000 nM
Compound 4: middle estimate off by 5.1-fold (0.71 log units), on the low side; measured number above the stated range.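

In this assay thiophen-2-yl in place of furan-2-yl on a carbonyl carbon gives a 6.1-fold higher number from compound 3 to compound 4 (0.79 log units; beyond the scatter) on the core of compound 3. For compound 1 the value > 2150000 nM is a limit and not a number. The same change from compound 1 to compound 2 therefore gives no readable step, and the series does not show whether the size of the step carries from one core to the other, because that comparison rests on a limit: the limit of > 2150000 nM in this assay, at which 1 of the 4 values shown sits.

The compounds shown leave open how a phenyl ring or a longer alkyl chain would read in place of these five-membered aromatic rings on either core. They also leave open what an amine on that carbonyl carbon would give.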